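The source may hold more compounds than are shown below. What is called first, only, known or untested is meant among the compounds shown, and "the series" means these compounds.

Compound 1 `COc1cccc2cc(C(=O)NC3CCCCC3)c(=N)oc12` is one of three compounds tested in an assay on CHO cells for displacement of a labelled ligand from adenosine receptor A1 (Homo sapiens), read by scintillation counting, with a stated time of 60 min, tested at 10 uM; on this read-out lower numbers stand for less inhibition and higher numbers for more inhibition at the one concentration tested (going by the name of the read-out). In this assay compound 1 gives 40%. Compound 2 `COc1cccc2cc(C(=O)Nc3c(C#N)ncn3-c3ccc(F)cc3)c(=N)oc12` gives 46% in this assay, and compound 3 `N=c1oc2ccc(Br)cc2cc1C(=O)NCCCO` gives 32% in this assay. Within the data shown here, both of these numbers lie within the usual scatter of the value of compound 1, so on these data the three compounds cannot be separated, and no single-change step between measured compounds is available to guide an expectation. Compound 4 `COc1cccc2cc(C(=O)NC(CO)(CO)CO)c(=N)oc12` has not yet been measured in this assay. It differs from compound 1 in one place: 2-hydroxy-1,1-bis(hydroxymethyl)ethyl in place of cyclohexyl on an amide-type nitrogen. Compound 4 is expected to show a fall somewhat beyond the scatter, a number 20 percentage points lower from compound 1 to compound 4 (beyond the scatter). The estimate for compound 4 in this assay is 20%, with a range from 5% to 38%.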

Compound 4, a percentage reported as inhibition, at one concentration (the size of the read-out at that concentration, not a potency): 19%
Beside the measured number, compound 4's estimate is 1 percentage points above it, within the range that was stated.
By their numbers in this assay, from the lowest: compound 4; then compounds 3, 1 and 2 (each within the scatter of the next, the first and the last beyond it).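

Among these compounds, replacing cyclohexyl with 2-hydroxy-1,1-bis(hydroxymethyl)ethyl on the amide-type nitrogen gives, in this assay, a number 21 percentage points lower from compound 1 to compound 4 (beyond the scatter), the first single-place step in this set and the first difference from compound 1 beyond the scatter. The group on this nitrogen therefore bears on the read-out, and here the open-chain triol goes with less inhibition at the one concentration tested. No measurement at hand explains this fall.

Losing the ring and gaining the hydroxyl groups happen together in this step, so the compounds shown do not tell which of the two goes with the fall. A tert-butyl group or a hydroxycyclohexyl group on this nitrogen would pull the two apart.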